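Swapping the pyridine on the amide of a pyrazoline

The compounds below may be only part of what the source reports. "The series", "measured", "known", "first", "only" and "open" are said of these compounds alone.

Of the compounds shown here, two of a shared core have been measured in a functional assay on WM 266-4 cells (Homo sapiens) for antiproliferative activity, read by MTT assay, with a stated time of 24 h; on this read-out lower numbers stand for stronger inhibition of growth and higher numbers for weaker inhibition of growth. Compound 1 `COc1ccc(C2=NN(C(=O)c3ccc(C)nc3Cl)C(c3ccc(OC)cc3)C2)cc1` gives 5740 nM in this assay. Compound 2 `COc1ccc(C2=NN(C(=O)c3cncc(Br)c3)C(c3ccc(OCc4ccccc4)cc3)C2)cc1` gives 6240 nM in this assay. Compound 2 thus has the higher of the two numbers, but its nearest neighbour, compound 1, lies within the usual scatter of it, so the two cannot be told apart on these results. For the measured compounds named here, the two compounds differ in two places at once, so no single step between them can be read off.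

Compound 3 `COc1ccc(C2=NN(C(=O)c3ccc(C)nc3Cl)C(c3ccc(OCc4ccccc4)cc3)C2)cc1` is not yet measured. It differs from compound 2 in one place: 2-chloro-6-methylpyridin-3-yl in place of 5-bromopyridin-3-yl on a carbonyl carbon. The same pyridine already sits on compound 1, which gives a number close to that of compound 2. Going by the values given here, with only two measured compounds, both close together, no change beyond the scatter is expected in this assay. The step from compound 2 to compound 3 is expected to be a 1.0-fold lower number from compound 2 to compound 3 (0.02 log units; within the scatter). For compound 3 the estimate in this assay is 6000 nM, with a range from 2500 nM to 14000 nM.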

Compound 3, concentration for 50% growth inhibition: 10500 nM
Beside the measured number, compound 3's estimate is 1.8-fold (0.24 log units) below it; measured number inside the range.
By their numbers in this assay, from the lowest: compounds 1, 2 and 3 (each within the scatter of the next).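

In this assay, for the compounds shown here, the comparison of compound 2 with compound 3 is the first that changes only one place: putting 2-chloro-6-methylpyridin-3-yl in place of 5-bromopyridin-3-yl on a carbonyl carbon gives a 1.7-fold higher number from compound 2 to compound 3 (0.23 log units; within the scatter), so on these results the two pyridines cannot be told apart at this position. The second single change, phenyl in place of hydrogen on a saturated chain carbon bound to an oxygen on an aromatic ring, gives a 1.8-fold higher number from compound 1 to compound 3 (0.26 log units; within the scatter), so this change also cannot be separated from the variation between repeated measurements. No supporting measurement is available to explain either result.

Going by these compounds, it remains open whether a simple phenyl ring, or a pyridine carrying an amine, on the same carbonyl carbon would shift the number beyond the scatter. On these data alone, it is equally open whether a longer chain or a carboxylic acid in place of the phenyl on that saturated chain carbon would do so.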